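This account rests on a few compounds, and the source may have more. Where it says the series, first, only, none or still open, it means among the compounds named here.

Measured in a functional assay on KB cells (Homo sapiens) for antiproliferative activity, read by sulforhodamine B assay, with a stated time of 48 h; on this read-out higher numbers stand for weaker inhibition of growth and lower numbers for stronger inhibition of growth:
Compound 1 `COc1ccc(S(=O)(=O)Nc2ccccc2CCc2ccc(C(=O)Nc3ccccc3)cc2)cc1`: 137 nM
Compound 2 `COc1ccc(S(=O)(=O)Nc2ccccc2CCc2ccc(C(=O)Nc3cc(F)ccc3N)cc2)cc1`: 66 nM

Of the two measured compounds, compound 2 has the lower number in this assay, at 66 nM, and so shows the stronger inhibition of growth. The next compound to be tested is compound 3 `COc1ccc(S(=O)(=O)Nc2ccccc2CCc2ccc(C(=O)Nc3cccc(N)c3)cc2)cc1`, which differs from compound 2 by 3-aminophenyl in place of 2-amino-5-fluorophenyl on an amide-type nitrogen. In words, this places 3-aminophenyl in place of 2-amino-5-fluorophenyl on an amide-type nitrogen.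

Within the data shown here, only one measured step bears on this change: a 2.1-fold lower number from compound 1 to compound 2 (0.32 log units; beyond the scatter). That modest step replaced phenyl with 2-amino-5-fluorophenyl at the same place. Among the measured compounds shown here, no measured compound carries 3-aminophenyl, so the evidence is indirect. Compound 3 keeps an amino group on the ring but loses the 2-amino-5-fluorophenyl group, so it is expected to return part of the way towards compound 1.

The expected change is a 1.7-fold higher number from compound 2 to compound 3 (0.22 log units; within the scatter), a rise no larger than the measured step and perhaps not clear of the scatter. The estimated value for compound 3 is 110 nM, with an expected range from 45 nM to 280 nM.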

Compound 3, concentration for 50% growth inhibition: 697 nM
For compound 3 the middle estimate is 6.3-fold (0.80 log units) below the measured one; measured number outside the range, above it.
By their numbers in this assay, from the lowest: compound 2; then compound 1; then compound 3.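

In this assay, the group on the amide-type nitrogen proves far more sensitive than the earlier step suggested, with 3-aminophenyl in place of 2-amino-5-fluorophenyl giving a large loss (an 11-fold higher number from compound 2 to compound 3 (1.02 log units; beyond the scatter)). An amino group on this ring is thus not enough on its own to improve on the plain phenyl: adding one as in 3-aminophenyl moves the number the opposite way from the earlier gain (a 5.1-fold higher number from compound 1 to compound 3 (0.71 log units; beyond the scatter)), and compound 3 ends up the weakest of the three. No measurement at hand explains this reversal.

The step from compound 2 to compound 3 changes both the fluorine and the place of the amino group on the ring, so a 2-aminophenyl group without the fluorine would be needed to tell their shares apart. Going by these compounds, it also remains open whether a hydroxyl or a methyl group in place of the amino group would sit closer to compound 1 or to compound 3 in this assay.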